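Swapping the Amide Head Group of Compound 2

The source may report more compounds than this note shows. Statements on the series, on what has been measured and on what is new or still open speak of the compounds shown alone.

Measured so far:
Compound 1, `Cc1ccc2[nH]c(C(=O)N[C@H]3CN(S(=O)(=O)c4cnccn4)C[C@@H]3C(=O)NCCN(C)C)cc2c1`, in a physicochemical assay for lipophilicity, measured as octanol-water partition, at pH 7.4 (on this read-out lower numbers stand for lower lipophilicity and higher numbers for higher lipophilicity), compound 1 gives 1.
Compound 2, `O=C(N[C@H]1CN(S(=O)(=O)c2ccccc2)C[C@@H]1C(=O)N[C@H]1CCCNC1)c1cc(C2CC2)n[nH]1`, in this assay compound 2 gives 0.2.

Among the measured compounds shown here, only two compounds have numbers here, and compound 2 holds the lower of them; compound 1 sits higher by a gap that lies beyond the usual scatter of this kind of measurement. For the measured compounds named here, the two compounds differ in several places at once, so no single step between them can be traced, and their two values are all that is known.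

Compound 3, `O=C(N[C@H]1CN(S(=O)(=O)c2ccccc2)C[C@@H]1C(=O)N[C@H]1CCCNC1)c1cc(-c2ccccc2Cl)on1`, has not yet been measured. It differs from compound 2 in one place: a group of 12 heavy atoms (9 carbon, 1 nitrogen, 1 oxygen, 1 chlorine; one five-membered aromatic ring with 2 hetero atoms, one six-membered aromatic ring of carbon only) in place of a group of 8 heavy atoms (6 carbon, 2 nitrogen; one three-membered non-aromatic ring of carbon only, one five-membered aromatic ring with 2 hetero atoms), on a carbonyl carbon. Going by the values given here, since no measured pair of compounds differs in only one place, there is no measured step on which to lean, and the expectation that follows rests on the change itself and on the starting point of compound 2 at 0.2.

The change from compound 2 to compound 3 is expected to be a sizeable upward step, a number 1.30 log units higher from compound 2 to compound 3 (beyond the scatter), clearly beyond the scatter. Compound 3 is therefore estimated at 1.5, with a likely range from 0.9 to 2.1.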

Compound 3, distribution coefficient: 1.9
For compound 3 the middle estimate is 0.40 log units below the measured one, and the stated range covers the measured number.
By their numbers in this assay, from the lowest: compound 2; then compound 1; then compound 3.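

Among the compounds shown here, this is the first step in this assay that can be traced to one place. On a carbonyl carbon whose other neighbour is an amide-type nitrogen, putting the new group in place of 3-cyclopropyl-1H-pyrazol-5-yl gives a number 1.70 log units higher from compound 2 to compound 3 (beyond the scatter), so this one position can move the read-out by a large amount while the rest of the molecule stays the same. The change bundles several differences, as the group grows from 8 to 12 heavy atoms, gains a chlorine and a six-membered aromatic ring of carbon only, and goes from 1 hydrogen-bond donor to 0, and no measurement at hand ties the size of the step to any of these.

Still open, from the compounds shown here alone, is how the step divides among those differences, for instance whether the same group with hydrogen or fluorine in place of the chlorine would stay close to compound 3. Also open, going by these compounds, is whether the same swap gives a similar step on other molecules, such as one carrying the dimethylaminoethyl amide chain in place of the piperidine-bearing amide.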